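The compounds below may be only part of what the source reports. "The series", "measured", "known", "first", "only" and "open" are said of these compounds alone.

Among the compounds with values here, in a functional assay on HCT-116 cells (Homo sapiens) for antiproliferative activity, read by MTT assay, with a stated time of 72 h (a higher number here means a weaker inhibitor, a lower number a stronger inhibitor), compound 1 (`COc1cc(CCc2ccccc2)cc(OC)c1O`) gives 530 nM and compound 2 (`COc1cc(CCc2ccccc2Cl)cc(OC)c1O`) gives 250 nM as the lower of the two numbers so far. Compound 3 (`COc1cc(CCc2ccccc2F)cc(OC)c1O`) has fluoro in place of chloro on an aromatic carbon, ortho to a large group (fluoro in place of chloro on an aromatic carbon). Within the data shown here, the one measured step bearing on this change is modest (a 2.1-fold lower number from compound 1 to compound 2 (0.33 log units; beyond the scatter)) and puts chloro in place of hydrogen on that carbon. Among the measured compounds shown here, no fluoro compound has been measured, so in this assay only a small step toward a higher number is expected, possibly within the scatter. The estimated step is a 1.4-fold higher number from compound 2 to compound 3 (0.15 log units; within the scatter) on this reading. For compound 3 the expected value is 350 nM (estimated range 180 nM to 680 nM).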

Compound 3, half-maximal inhibitory concentration: 880 nM
Beside the measured number, compound 3's estimate is 2.5-fold (0.40 log units) below it, outside the stated range (above it).
By their numbers in this assay, from the lowest: compound 2; then compounds 1 and 3 (each within the scatter of the next).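

On an aromatic carbon ortho to a large group, chloro and fluoro are not interchangeable (a 3.5-fold higher number from compound 2 to compound 3 (0.55 log units; beyond the scatter)). Fluoro in place of hydrogen gives no change that can be separated from the scatter (a 1.7-fold higher number from compound 1 to compound 3 (0.22 log units; within the scatter)), so the modest gain seen with chloro in compound 2 does not carry over to fluoro in compound 3. Nothing available accounts for this difference between the two halogens.

As far as these compounds go, whether the gain extends to other groups on this carbon remains open, for example bromo, methyl or an amine. From the compounds shown here alone, whether chloro gives the same step elsewhere on the ring also remains open.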